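The compounds below may be only part of what the source reports. "The series", "measured", "known", "first", "only" and "open" are said of these compounds alone.

Of the compounds shown here, two have numbers so far in an ADME assay on S9 fraction from liver (Rattus norvegicus) for metabolic stability, with a stated time of 1 h; a lower number here means that less of the compound is left, a higher number that more of the compound is left. Compound 1 `CO[C@H]1CC[C@@H](Nc2cc(NCc3cnccc3C(F)(F)F)ncc2C#N)CC1` gives 1%, while compound 2 `CC(C)(F)c1ncncc1CNc1cc(N[C@H]2CC[C@@H](O)CC2)c(C#N)cn1` gives 81%. Compound 2 therefore holds the higher of the two numbers, and the gap between them lies beyond the usual scatter. The two structures differ in more than one place, so this gap cannot be tied to any single group.

Still to be measured is compound 3 `N#Cc1cnc(NCc2cncnc2OCC(F)F)cc1N[C@H]1CC[C@@H](O)CC1`, which differs from compound 2 at one place: 2,2-difluoroethoxy in place of 1-fluoro-1-methylethyl on an aromatic carbon. In words, 2,2-difluoroethoxy stands in place of 1-fluoro-1-methylethyl on an aromatic carbon. Going by the values given here, no measured pair shows a swap of this kind, so any expectation here is loose. With compound 2 at 81%, little room remains upward on this scale, and a moderate fall seems more likely than a rise. The expected change is a number 19 percentage points lower from compound 2 to compound 3 (beyond the scatter), and this estimate carries wide uncertainty. For compound 3 the estimated value is 62%, with an expected range from 30% to 87%.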

Compound 3, percent of the compound remaining: 79%
The estimate for compound 3 lay 17 percentage points below the measured number; the range from low to high includes it.
By their numbers in this assay, from the lowest: compound 1; then compounds 3 and 2 (each within the scatter of the next).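

In this assay, going by these compounds alone, the change to 2,2-difluoroethoxy in place of 1-fluoro-1-methylethyl gives a number 2 percentage points lower from compound 2 to compound 3 (within the scatter), the first step in this set that can be tied to a single place. So at this aromatic carbon next to the ring nitrogen, two quite different groups, one joined through carbon and the other through oxygen, leave the number unchanged within the scatter, and the fraction of compound left stays high for both. The data shown offer no measurement that explains why the number holds at this position.

Going by these compounds, it remains open how far this tolerance extends, for instance whether an amine, a carboxylic acid or a longer alkoxy chain at the same carbon would give a similar number. The large gap between compound 1 and the other two also remains unassigned, as compound 1 differs from compound 2 in more than one place and no single change links them.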